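Changing the pendant ring on a shared core: cytotoxicity

The source may report more compounds than this note shows. Statements on the series, on what has been measured and on what is new or still open speak of the compounds shown alone.

Compound 1, `Cc1ccc(-c2ccc3[nH]c(=O)nc(-c4ccccc4)c3c2)cn1`, in an ADME assay on THP-1 cells (Homo sapiens) for cytotoxicity, read by MTT assay, with a stated time of 72 h (a higher number here means that more compound is needed for the effect, a lower number that less compound is needed), compound 1 gives > 50000 nM, which is a limit of the assay and not a number.
Compound 2, `O=c1nc(-c2ccccc2)c2cc(-c3ccccc3)ccc2[nH]1`, gives > 50000 nM, again a limit.
Compound 3, `O=c1nc(-c2ccccc2)c2cc(-c3cncnc3)ccc2[nH]1`, gives > 50000 nM, again a limit.

Compound 1 therefore stands at the limit, as do the other two values (the limit of > 50000 nM in this assay, at which 3 of the 3 values shown sit). Compound 4, `O=c1nc(-c2ccccc2)c2cc(-c3cn[nH]c3)ccc2[nH]1`, differs from compound 1 in one place: 1H-pyrazol-4-yl in place of 6-methylpyridin-3-yl on an aromatic carbon. For the measured compounds named here, the steps that bear on this are a step that the two limits leave unreadable from compound 1 to compound 2, a step that the two limits leave unreadable from compound 1 to compound 3 and a step that the two limits leave unreadable from compound 2 to compound 3, none of which can be sized. No step beyond the scatter is expected in this assay, and the step from compound 1 to compound 4 is estimated at a step that the limit leaves unreadable from compound 1 to compound 4. Compound 4 is expected to give 60000 nM, within 25000 nM to 200000 nM, most likely again as a limit.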

Compound 4, half-maximal effective concentration: > 50000 nM
Compound 4: no number, only a limit (the forecaster's own chance of this, stated with the estimate: 85%); the middle value is on the limit's open side.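

In this assay compound 4 gives > 50000 nM, a limit and not a number. The steps from compound 1, compound 2 and compound 3 to compound 4 therefore cannot be read: the limit of > 50000 nM in this assay, at which 4 of the 4 values shown sit.

Going by these compounds, whether these pendant rings differ at all in this assay stays open.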